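Swapping the Fused Heteroaryl Amide in a Sulfone Series

A few compounds are considered here, and "the series" means these few. Any claim that something is new, unique, unknown or untested is made for them only; others in the source may bear on it.

Measured so far:
compound 1, `O=C(NCc1ccc(S(=O)(=O)c2ccccc2)cc1)c1ccc2ccncc2c1`, > 10000 nM
compound 2, `O=C(NCc1ccc(S(=O)(=O)c2ccccc2)cc1)c1cc2ccncc2s1`, 14 nM
compound 3, `O=C(NCc1ccc(S(=O)(=O)c2cccc(C(F)(F)F)c2)cc1)c1cnc2nccn2c1`, 2 nM

In a functional assay on A2780 cells (Homo sapiens) for inhibition, read by sulforhodamine B assay, with a stated time of 72 h (on this read-out lower numbers stand for stronger inhibition and higher numbers for weaker inhibition), compound 1 returns only a limit, > 10000 nM, and no number. Compound 2 gives 14 nM in this assay, the higher of the two numbers in hand. Compound 3, which also carries a trifluoromethyl group on its sulfone ring, gives 2 nM, a lower number than compound 2 by a gap that lies beyond the usual scatter.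

Compound 4, `O=C(NCc1ccc(S(=O)(=O)c2ccccc2)cc1)c1nc2ccncc2s1`, has not yet been measured. It differs from compound 2 only at the carbonyl carbon, where (a group of 9 heavy atoms (6 carbon, 2 nitrogen, 1 sulfur; one five-membered aromatic ring with 2 hetero atoms, one six-membered aromatic ring with 1 hetero atom) in place of a group of 9 heavy atoms (7 carbon, 1 nitrogen, 1 sulfur; one five-membered aromatic ring with 1 hetero atom, one six-membered aromatic ring with 1 hetero atom), on a carbonyl carbon). The group that enters keeps the same ring sizes and the same number of heavy atoms but carries one more nitrogen and one more hydrogen-bond acceptor.

Going by the values given here, no measured pair in this set isolates that change, so the expectation rests on compound 2 alone. Compound 4 is expected to give about 25 nM in this assay, between 5 nM and 150 nM. The expected step from compound 2 to compound 4 is therefore a 1.8-fold higher number from compound 2 to compound 4 (0.25 log units; within the scatter), that is, little beyond the scatter and, if anything, a slight weakening.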

Compound 4, half-maximal inhibitory concentration: > 10000 nM
Compound 4: no number, only a limit; the forecaster's own chance of this, stated with the estimate: 5%; middle value at least 400-fold (2.60 log units) away from the limit.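

At the carbonyl carbon, a group with the same ring sizes and heavy-atom count but one more nitrogen gives an at least 710-fold higher number from compound 2 to compound 4 (2.85 log units; beyond the scatter) in this assay. So this position can respond very strongly to a single atom change, something the earlier compounds, with no matched pair among them, could not show. Compound 4 returns only a limit, so the full size of this step cannot be read: the limit of > 10000 nM in this assay, at which 2 of the 4 values shown sit.

No measured property of the added nitrogen is available, so the reason for the loss remains unknown. The compounds shown leave open whether activity would return with a methyl group or an amine on the five-membered aromatic ring of compound 4, or with the trifluoromethyl group carried by compound 3 on the sulfone ring.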